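This account rests on a few compounds, and the source may have more. Where it says the series, first, only, none or still open, it means among the compounds named here.

Compound 1 `COc1cccc(/C=C/C(=O)c2cccc(C(F)(F)F)c2)c1OC`: 0%
Compound 2 `COc1cccc(/C=C/C(=O)c2ccccc2C(F)(F)F)c1OC`: 0%
Compound 3 `COc1cccc(/C=C/C(=O)c2ccc(SC)cc2)c1OC`: 0%

All three measured compounds share one core and differ only in the group carried on the ring attached to the carbonyl. In an assay for inhibition of Amine oxidase [flavin-containing] A (Homo sapiens), read by spectrophotometry, using microsomes, with a stated time of 5 min, tested at 10 uM (a higher number here means more inhibition at the concentration tested (going by the name of the read-out), a lower number less inhibition), compound 1 gives 0%, and it stands level with compound 2 and compound 3 at the digits reported, the differences to both lying within the usual scatter of such measurements. In this assay compound 2 gives 0% and compound 3 gives 0%. None of the three shows inhibition that can be told from no effect, so no ranking among them can be drawn.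

Among the measured compounds shown here, the next compound, compound 4 `COc1cccc(/C=C/C(=O)c2cccc(OC(F)(F)F)c2)c1OC`, keeps the core of compound 1 and changes only one group: trifluoromethoxy in place of trifluoromethyl on an aromatic carbon. For the measured compounds named here, the measured compounds are all at the floor of this assay, so there is no measured step from which a direction could be read. The change is a small one on the same ring. The step expected from this change is a number 2 percentage points higher from compound 1 to compound 4 (within the scatter), that is, none beyond the scatter. Compound 4 is therefore estimated to give 2%, with a range from 0% to 15%.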

Compound 4, a percentage reported as inhibition, at one concentration (the size of the read-out at that concentration, not a potency): 0%
Compound 4: the middle estimate sits 2 percentage points above what was measured, and the stated range covers the measured number.
By their numbers in this assay, from the lowest: compounds 1, 2, 3 and 4 (each within the scatter of the next).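

In this assay, trifluoromethoxy in place of trifluoromethyl on an aromatic carbon brings no change at the digits printed from compound 1 to compound 4 (within the scatter) and gives the series its first pair of compounds that differ in one place. The new group adds an oxygen and a hydrogen-bond acceptor, yet this pair still shows no inhibition that can be told from no effect, so this swap at this position does not separate the two compounds in this read-out. Since both compounds of the pair sit at the bottom of the read-out, the step says nothing about how either group would behave in a compound with measurable inhibition, and nothing available here offers an explanation for the result.

Going by these compounds, what stays open is whether any group at this position can produce measurable inhibition, for instance an amine or a carboxylic acid in place of trifluoromethyl on the same aromatic carbon. With all the compounds shown reading alike, the results also cannot say whether changes elsewhere on the shared core would matter more than changes on this ring.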